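The source may report more compounds than this note shows. Statements on the series, on what has been measured and on what is new or still open speak of the compounds shown alone.

Measured compounds:
compound 1, `Cc1ccc([C@@H](C)Oc2cc3onc(CCC(=O)O)c3cc2Cl)nc1`, 1.59 nM
compound 2, `C[C@@H](Oc1cc2onc(CCC(=O)O)c2cc1Cl)c1ccc(F)cn1`, 31.6 nM
compound 3, `Cc1ccnc([C@@H](C)Oc2cc3oc(=O)n(CCC(=O)O)c3cc2Cl)c1`, 31600 nM

In an assay on HEK293 cells for inhibition of kynurenine 3-monooxygenase (Homo sapiens), read by LC-MS, with a stated time of 20 h (on this read-out lower numbers stand for stronger inhibition and higher numbers for weaker inhibition), compound 3 stands at the highest number of the three, above compound 2 and far above compound 1, both gaps lying beyond the scatter. Compound 4, `C[C@@H](Oc1cc2oc(=O)n(CCC(=O)O)c2cc1Cl)c1ncccn1`, differs from compound 3 by one change: pyrimidin-2-yl in place of 4-methylpyridin-2-yl on a saturated chain carbon bound to an oxygen on an aromatic ring and a saturated chain carbon. Among the compounds with values here, only one measured step touches this change: a 20-fold higher number from compound 1 to compound 2 (1.30 log units; beyond the scatter), where the methyl on the aromatic carbon of the aryl group gave way to fluoro, and that step was large toward weaker inhibition. Compound 4 likewise loses the methyl on the aryl group while the ring gains a second nitrogen. On this basis the step from compound 3 to compound 4 in this assay is expected to run toward a higher number, though compound 3 already sits so high that the assay may report only a limit; the expected step is a 1.9-fold higher number from compound 3 to compound 4 (0.28 log units; within the scatter). Compound 4 is therefore estimated at 60000 nM, in the range 12000 nM to 300000 nM.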

Compound 4, half-maximal inhibitory concentration: 3160 nM
The estimate for compound 4 lay 19-fold (1.28 log units) above the measured number; measured number below the stated range.
By their numbers in this assay, from the lowest: compound 1; then compound 2; then compound 4; then compound 3.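

In this assay, the change at this saturated chain carbon gave a 10-fold lower number from compound 3 to compound 4 (1.00 log units; beyond the scatter), a step beyond the scatter toward stronger inhibition. Within the data shown here, the only earlier step at this aryl group, a 20-fold higher number from compound 1 to compound 2 (1.30 log units; beyond the scatter), ran the other way, so across these two pairs, which have different cores and different replacing groups, losing the methyl from the aryl group did not bring one fixed direction. Nothing available explains the size or direction of the new step.

The compounds shown leave open whether the step follows the lost methyl or the additional ring nitrogen, as the two change together in pyrimidin-2-yl. From the compounds shown here alone, it also remains open how an unsubstituted pyridin-2-yl would stand at this place, and whether pyrimidin-2-yl would shift the number in the same direction on the core of compound 1.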